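A few compounds are considered here, and "the series" means these few. Any claim that something is new, unique, unknown or untested is made for them only; others in the source may bear on it.

Compound 2 `CN(C)/N=N/c1cccc(C(N)=O)c1` gives 3.8 in a functional assay on L1210 cells (Mus musculus) for antiproliferative activity (a lower number here means a less potent compound, a higher number a more potent compound, by a factor of ten per unit of this negative logarithm), and stands within the scatter of compound 1 `COc1ccc(C(N)=O)cc1/N=N/N(C)C`, which gives 3.95; the step of a number 0.15 log units lower from compound 1 to compound 2 (within the scatter) is the only measured one so far. Compound 3 `CC(=O)c1cccc(/N=N/N(C)C)c1` differs from compound 2 by methyl in place of amino on a carbonyl carbon. Among the measured compounds shown here, no measured step changes anything on a carbonyl carbon, and the one known step, on an aromatic carbon, was within the scatter. The change to compound 3 is therefore expected to give a step of no change at the digits printed from compound 2 to compound 3 (within the scatter) in this assay. Compound 3 is estimated at 3.8, with a range from 3.2 to 4.4.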

Compound 3, logarithm of the reciprocal of the active concentration, log(1/C): 3.58
Beside the measured number, compound 3's estimate is 0.22 log units above it; the range from low to high includes it.
By their numbers in this assay, from the lowest: compounds 3, 2 and 1 (each within the scatter of the next, the first and the last beyond it).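

Methyl in place of amino on a carbonyl carbon, carbamoyl to acetyl, gives a number 0.22 log units lower from compound 2 to compound 3 (within the scatter) in this assay and is the only step shown at this position. It shows that here the amino group, with its hydrogen-bond donor, can give way to methyl without a step beyond the scatter. No measurement shown bears on what lies behind this number.

Open, from the compounds shown here alone, is how a carboxylic acid, a methyl ester or a longer chain such as propanoyl on this carbonyl carbon would read in this assay against compound 2, and whether a dimethylamino group there would read as the amino group does.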